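Series notes: replacing the 1,3-dicarboxypropyl group

A few compounds are considered here, and "the series" means these few. Any claim that something is new, unique, unknown or untested is made for them only; others in the source may bear on it.

Measured in a functional assay on SW-620 cells (Homo sapiens) for antiproliferative activity, read by MTT assay, with a stated time of 72 h, in the presence of a further agent that is not named here; on this read-out lower numbers stand for stronger inhibition and higher numbers for weaker inhibition:
compound 1 `Nc1nc2[nH]c(CCSCC(=O)N[C@@H](CCC(=O)O)C(=O)O)cc2c(=O)[nH]1` (442 nM)
compound 2 `Nc1nc2[nH]c(CCSCCC(=O)NCc3ccncc3)cc2c(=O)[nH]1` (24800 nM)

Compound 1 holds the lower of the two numbers, and compound 2 lies higher by a margin beyond the scatter. Unmeasured compound 3 `Nc1nc2[nH]c(CCSCC(=O)NCc3ccccn3)cc2c(=O)[nH]1` carries (pyridin-2-yl)methyl in place of 1,3-dicarboxypropyl on an amide-type nitrogen. Within the data shown here, no measured step covers this change. A large step to higher numbers, beyond the scatter, is expected in this assay; this rests only on compound 2 (24800 nM), the higher of the two numbers. The estimated change is a rise (a 27-fold higher number from compound 1 to compound 3 (1.43 log units; beyond the scatter)). For compound 3 the expected value is 12000 nM (estimated range 2000 nM to 50000 nM).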

Compound 3, half-maximal inhibitory concentration: 36100 nM
Compound 3: middle estimate off by 3.0-fold (0.48 log units), on the low side; the range from low to high includes it.
By their numbers in this assay, from the lowest: compound 1; then compounds 2 and 3 (each within the scatter of the next).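

On the amide-type nitrogen, (pyridin-2-yl)methyl in place of 1,3-dicarboxypropyl brings a large loss of inhibition in this assay, an 82-fold higher number from compound 1 to compound 3 (1.91 log units; beyond the scatter), giving the series its first change in one place. The exchange removes the hydrogen-bond donors and the defined stereocentre of the leaving group together, so the step cannot separate these features. Nothing available explains the size of this step. Open, from the compounds shown here alone, is whether a single carboxylic acid on a shorter chain, or a plain benzyl group, on that nitrogen would retain the inhibition of compound 1.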